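Meta-halophenyl pair across two cores in breast panel

The source may report more compounds than this note shows. Statements on the series, on what has been measured and on what is new or still open speak of the compounds shown alone.

Measured compounds:
compound 1 `Cc1cc(C)c2c(O)cc(-c3cccc(F)c3)nc2n1` — 1000 nM
compound 2 `Cc1cc(C)c2c(O)cc(-c3cccc(Cl)c3)nc2n1` — 1230 nM
compound 3 `Cc1cnc2[nH]c(-c3cccc(Cl)c3)cc(=O)c2c1` — 12900 nM

In a functional assay on cells (Panel breast (Carcinoma cell lines), Homo sapiens) for inhibition (on this read-out higher numbers stand for weaker inhibition of growth and lower numbers for stronger inhibition of growth), compound 1 gives 1000 nM and compound 2 gives 1230 nM. The change between them, (fluoro in place of chloro on an aromatic carbon), made a 1.2-fold lower number from compound 2 to compound 1 (0.09 log units; within the scatter). Compound 3 carries the same chloro substituent on a different core; in this assay compound 3 gives 12900 nM, the highest number of the three. The difference between the core of compound 2 and the core of compound 3 is not broken down here.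

Compound 4 `Cc1cnc2[nH]c(-c3cccc(F)c3)cc(=O)c2c1` is not yet measured. It differs from compound 3 by fluoro in place of chloro on an aromatic carbon, the same change as from compound 2 to compound 1. Because a 1.2-fold lower number from compound 2 to compound 1 (0.09 log units; within the scatter) lay within the scatter, a step of similar size, a 1.2-fold lower number from compound 3 to compound 4 (0.09 log units; within the scatter), is expected here as well. For compound 4 in this assay the estimate is 10500 nM, with a range from 5000 nM to 22000 nM.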

Compound 4, concentration for total growth inhibition: 537 nM
Compound 4: middle estimate off by 20-fold (1.29 log units), on the high side; measured number outside the range, below it.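

In this assay, fluoro in place of chloro on an aromatic carbon gave a 24-fold lower number from compound 3 to compound 4 (1.38 log units; beyond the scatter), so the step seen on one core did not carry over in size to the other: the same change on two cores in this assay, a 1.2-fold lower number (0.09 log units; within the scatter) from compound 2 to compound 1 and a 24-fold lower number (1.38 log units; beyond the scatter) from compound 3 to compound 4, 20-fold (1.29 log units) apart, beyond the scatter of two such steps. In these two pairs, the effect of this change depends on the core, and a step read on one core gives no safe estimate for the other. The data do not show what in the two cores sets this difference, and they rest on a single pair per core.

Open, as far as these compounds go, is whether a nitrile or an amine at the same place would also respond differently on the two cores. Also open, from the compounds shown here alone, is how the unsubstituted phenyl compares on each core.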